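A few compounds are considered here, and "the series" means these few. Any claim that something is new, unique, unknown or untested is made for them only; others in the source may bear on it.

Measured so far:
Compound 1 `CNc1nc(NCCCN(C)C)c2sc(-c3ccc(C(F)(F)F)cc3)cc2n1`: 240 ug/mL in a physicochemical assay for solubility, at pH 2; on this read-out lower numbers stand for lower solubility and higher numbers for higher solubility
Compound 2 `CNc1nc(NC2CC2)c2sc(-c3ccc(C(F)(F)F)cc3)cc2n1`: 120 ug/mL in this assay

Among the measured compounds shown here, compound 2 holds the lower of the two numbers, yet its only neighbour, compound 1, sits close: a 2.0-fold lower number from compound 1 to compound 2 (0.30 log units; within the scatter). Compound 3 `CNc1nc(Nc2cccc(S(C)(=O)=O)c2)c2sc(-c3ccc(C(F)(F)F)cc3)cc2n1` differs from compound 2 in one place: 3-(methylsulfonyl)phenyl in place of cyclopropyl on a nitrogen on an aromatic ring. For the measured compounds named here, no measured step concerns this exchange; the single step known, from compound 1 to compound 2, swapped a different group and stayed within the scatter. With nothing directly comparable, compound 3 is estimated at 30 ug/mL, ranging from 5 ug/mL to 120 ug/mL, which would be an expected downward step of a 4.0-fold lower number from compound 2 to compound 3 (0.60 log units; beyond the scatter).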

Compound 3, solubility: < 5 ug/mL
Compound 3: a limit, no number; the forecaster's own chance of this, stated with the estimate: 15%; at least 6.0-fold (0.77 log units) between middle value and limit.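

Compound 3 gives a limit and not a number in this assay: the limit of < 5 ug/mL in this assay, at which 1 of the 3 values shown sits.
Among the compounds shown here, the group on this nitrogen can therefore matter far more than the earlier pair suggested: 3-(methylsulfonyl)phenyl in place of cyclopropyl gives an at least 24-fold lower number from compound 2 to compound 3 (1.38 log units; beyond the scatter), and in place of 3-(dimethylamino)propyl it gives an at least 48-fold lower number from compound 1 to compound 3 (1.68 log units; beyond the scatter), the first steps here beyond the scatter.
Because of the limit, these steps fix only a minimum size.

From the compounds shown here alone, whether the fall goes with the phenyl ring or with its methylsulfonyl group stays open. A plain phenyl, or a phenyl carrying an amine, on this nitrogen would help separate the two.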